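This account rests on a few compounds, and the source may have more. Where it says the series, first, only, none or still open, it means among the compounds named here.

Measured so far:
Compound 1 `CCCCCc1cc(C)c(C(=O)N=C(N)N)cc1S(C)(=O)=O`, in a functional assay for inhibition of sodium/hydrogen exchanger (Oryctolagus cuniculus); on this read-out higher numbers stand for weaker inhibition and lower numbers for stronger inhibition: 27 nM
Compound 2 `Cc1cc(N2CCCC2)c(S(C)(=O)=O)cc1C(=O)N=C(N)N`, in this assay: 11 nM

Compound 2 gives the lower of the two numbers. Within the data shown here, the sole measured step is a 2.5-fold lower number from compound 1 to compound 2 (0.39 log units; beyond the scatter), which exchanged a pentyl chain for a pyrrolidine ring on an aromatic carbon. Compound 3 `Cc1cc(N2CCCCC2)c(S(C)(=O)=O)cc1C(=O)N=C(N)N` differs from compound 2 in that same place: piperidin-1-yl in place of pyrrolidin-1-yl on an aromatic carbon. That one step is a different kind of exchange, so it bears only loosely here. Going from a five-membered to a six-membered ring is expected to move this assay little: the expected step is a 1.4-fold higher number from compound 2 to compound 3 (0.13 log units; within the scatter). Compound 3 is therefore estimated at 15 nM, within 6 nM to 40 nM.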

Compound 3, half-maximal inhibitory concentration: 21 nM
For compound 3 the middle estimate is 1.4-fold (0.15 log units) below the measured one, within the range that was stated.
By their numbers in this assay, from the lowest: compounds 2, 3 and 1 (each within the scatter of the next, the first and the last beyond it).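

Within this assay the move from a five-membered to a six-membered ring gives a 1.9-fold higher number from compound 2 to compound 3 (0.28 log units; within the scatter) and putting piperidin-1-yl in place of pentyl gives a 1.3-fold lower number from compound 1 to compound 3 (0.11 log units; within the scatter) at the same aromatic carbon. Among these compounds, this position therefore shows no clear separation between the two rings, while the step beyond the scatter seen with pyrrolidin-1-yl in place of pentyl has no counterpart with piperidin-1-yl. Nothing available explains these results. Still open, on these data alone, is how a morpholine ring, a piperazine ring or an open-chain dimethylamino group would read at this position.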